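From methyl to methoxy: compound 3 to compound 4

A few compounds are considered here, and "the series" means these few. Any claim that something is new, unique, unknown or untested is made for them only; others in the source may bear on it.

Measured in a functional assay on OVCAR-3 cells (Homo sapiens) for inhibition, read by sulforhodamine B assay, with a stated time of 48 h; a higher number here means a weaker inhibitor of growth, a lower number a stronger inhibitor of growth:
Compound 1 `CCOC(=O)c1nn(-c2ccc(Cl)cc2)c(-c2ccc(OC)cc2)c1CNC(C)(C)C`: 35400 nM; > 523000 nM (2 entries)
Compound 2 `CC(C)(C)NCc1c(C(=O)O)nn(-c2ccc(Cl)cc2)c1-c1ccccc1`: 653000 nM
Compound 3 `Cc1ccc(-c2c(CNC(C)(C)C)c(C(=O)O)nn2-c2ccc(Cl)cc2)cc1`: > 629000 nM

In this assay, compound 3 gives only a limit, > 629000 nM, and no number of its own. Compound 1 shows (the several entries of compound 1 in this assay, 35400 nM; > 523000 nM (2 entries)), the second entry being a limit. Compound 4 `COc1ccc(-c2c(CNC(C)(C)C)c(C(=O)O)nn2-c2ccc(Cl)cc2)cc1` differs from compound 3 in one group: methoxy in place of methyl on an aromatic carbon. Among the compounds with values here, the one measured step of a similar kind is a step that the limit leaves unreadable from compound 2 to compound 3, so it offers no size to carry over. Within the data shown here, compound 2, at 653000 nM, supplies the only single number for the expectation. The estimated step is a step that the limit leaves unreadable from compound 3 to compound 4, expected to stay within the scatter. Compound 4 is expected at 650000 nM, with an estimated range from 250000 nM to 1000000 nM.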

Compound 4, concentration for 50% growth inhibition: 121000 nM
Estimate against measurement, compound 4: 5.4-fold (0.73 log units) above; measured number outside the range, below it.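

In this assay, within the data shown here, methoxy on the aromatic carbon para to a large group gives the first readable change at this position: an at least 5.1-fold lower number from compound 3 to compound 4 (0.71 log units; beyond the scatter), and a 5.4-fold lower number from compound 2 to compound 4 (0.73 log units; beyond the scatter). Both steps lie beyond the scatter, so growth inhibition does respond to the group placed here, with methoxy giving a stronger inhibitor than either hydrogen or methyl. Compound 3 gives only a limit, so the first step has no exact size: the limit of > 629000 nM in this assay, at which 1 of the 4 values shown sits.

Going by these compounds, whether a hydroxyl group, an amine or a chlorine atom at this position would give stronger inhibition remains open. The compounds shown also do not explain why methoxy has this effect.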